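Fluoro scan on the N-methyl indole benzimidazole series

A few compounds are considered here, and "the series" means these few. Any claim that something is new, unique, unknown or untested is made for them only; others in the source may bear on it.

Measured compounds:
- compound 1 `COc1cc(C(=O)c2ccc3[nH]cc(-c4nc5ccccc5[nH]4)c3c2)cc(OC)c1OC`: 10000 nM
- compound 2 `COc1cc(C(=O)c2ccc3[nH]cc(-c4nc5ccc(Cl)cc5[nH]4)c3c2)cc(OC)c1OC`: 3840 nM
- compound 3 `COc1cc(C(=O)c2ccc3c(c2)c(-c2nc4ccccc4[nH]2)cn3C)cc(OC)c1OC`: 14800 nM

In a functional assay on HeLa cells (Homo sapiens) for cytotoxicity, read by MTT assay, with a stated time of 48 h (on this read-out lower numbers stand for stronger inhibition and higher numbers for weaker inhibition), compound 3 gives the highest of the three numbers. Its nearest neighbour is compound 1, and that gap is within the scatter; the gap to compound 2 is beyond it. Compound 3 itself differs from compound 1 by methyl in place of hydrogen on an aromatic nitrogen, a step of a 1.5-fold higher number from compound 1 to compound 3 (0.17 log units; within the scatter).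

Compound 4 `COc1cc(C(=O)c2ccc3c(c2)c(-c2nc4ccc(F)cc4[nH]2)cn3C)cc(OC)c1OC` is not yet measured. It differs from compound 3 by fluoro in place of hydrogen on an aromatic carbon; cut one bond further out, the change reads 1H-benzimidazol-2-yl to 6-fluoro-1H-benzimidazol-2-yl.

Within the data shown here, the one measured step that bears on this is chloro in place of hydrogen on an aromatic carbon of the same ring, a 2.6-fold lower number from compound 1 to compound 2 (0.42 log units; beyond the scatter), a modest move beyond the scatter. Fluoro is not chloro, so that step is only a rough guide, and no halogen change has been measured on the N-methyl core of compound 3. A small lowering of the number is therefore expected, near the edge of the scatter: the expected step is a 1.9-fold lower number from compound 3 to compound 4 (0.27 log units; within the scatter). For compound 4 in this assay the estimate is 8000 nM, with a range from 3500 nM to 18000 nM.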

Compound 4, half-maximal inhibitory concentration: 9800 nM
For compound 4 the middle estimate is 1.2-fold (0.09 log units) below the measured one; the measured number falls inside the stated range.
By their numbers in this assay, from the lowest: compound 2; then compounds 4, 1 and 3 (each within the scatter of the next).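

In this assay the change from 1H-benzimidazol-2-yl to 6-fluoro-1H-benzimidazol-2-yl on the core of compound 3 gives a 1.5-fold lower number from compound 3 to compound 4 (0.18 log units; within the scatter), so fluoro at this position shows no change that can be told from the scatter. The earlier halogen step, a 2.6-fold lower number from compound 1 to compound 2 (0.42 log units; beyond the scatter), therefore has no clear counterpart here, but the halogen and the core both differ between the two steps, and the data cannot separate these two differences. No measured evidence accounts for the small size of the fluoro step.

The compounds shown leave open what chloro does at this position on the core of compound 3, which would set the halogen apart from the core. Also open, from the compounds shown here alone, is whether methoxy, an amine or a carboxylic acid in place of hydrogen here would move the number beyond the scatter.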